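A few compounds are considered here, and "the series" means these few. Any claim that something is new, unique, unknown or untested is made for them only; others in the source may bear on it.

Measured compounds:
compound 1 `COc1ccc(C(F)(F)F)cc1Nc1ncc(C(F)(F)F)c(N2Cc3cccc(N(C)S(C)(=O)=O)c3C2)n1` — 17200 nM
compound 2 `CN(c1cccc2c1CN(c1nc(Nc3cc(C(F)(F)F)cc(C(F)(F)F)c3)ncc1C(F)(F)F)C2)S(C)(=O)=O` — 9200 nM

In a functional assay on HeLa cells (Homo sapiens) for antiproliferative activity, read by spectrophotometry, with a stated time of 2 days (a lower number here means a stronger inhibitor of growth, a higher number a weaker inhibitor of growth), compound 1 gives 17200 nM. Compound 2 gives 9200 nM in this assay, and the two numbers lie within the scatter of each other, so neither can be set apart from the other. The unmeasured compound 3 `CN(c1cccc2c1CN(c1nc(Nc3cc(Cl)cc(C(F)(F)F)c3)ncc1C(F)(F)F)C2)S(C)(=O)=O` differs from compound 1 in one place: 3-chloro-5-(trifluoromethyl)phenyl in place of 2-methoxy-5-(trifluoromethyl)phenyl on a nitrogen on an aromatic ring. Compound 3 thereby comes to resemble compound 2 closely, and the numbers of compound 1 and compound 2 give no sign of a large step in either direction. The step of a 1.8-fold lower number from compound 1 to compound 3 (0.26 log units; within the scatter) is expected to be small, at most at the edge of the scatter, and if anything towards a lower number, since compound 2 gives 9200 nM. Compound 3 is therefore estimated at 9500 nM, with a range from 4000 nM to 22000 nM.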

Compound 3, concentration for 50% growth inhibition: 4300 nM
For compound 3 the middle estimate is 2.2-fold (0.34 log units) above the measured one; the measured number falls inside the stated range.
By their numbers in this assay, from the lowest: compound 3; then compounds 2 and 1 (each within the scatter of the next).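

In this assay, the group on the nitrogen on an aromatic ring now shows a change beyond the scatter: 3-chloro-5-(trifluoromethyl)phenyl in place of 2-methoxy-5-(trifluoromethyl)phenyl gives a 4.0-fold lower number from compound 1 to compound 3 (0.60 log units; beyond the scatter). The same group also responds to a single substituent, with chloro in place of trifluoromethyl on an aromatic carbon giving a 2.1-fold lower number from compound 2 to compound 3 (0.33 log units; beyond the scatter), a modest step that compound 1 and compound 2 alone could not show. No measurement at hand accounts for either step.

The step from compound 1 both removes the methoxy group and brings in the chloro group, and the compounds shown do not separate the two changes. From the compounds shown here alone, how an amine or a nitrile in place of the chloro group would read also remains open.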